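Chloro for hydrogen repeated on a second core

The compounds below may be only part of what the source reports. "The series", "measured", "known", "first", "only" and "open" are said of these compounds alone.

Compound 1 `ClCc1ccccc1Cn1cnc2c(Cl)nc(Cl)nc21` gives 1380 nM in a functional assay on MDA-MB-231 cells (Homo sapiens) for cytotoxicity, read by sulforhodamine B assay, with a stated time of 48 h; on this read-out higher numbers stand for weaker inhibition of growth and lower numbers for stronger inhibition of growth. Compound 2 `ClCc1ccccc1Cn1cnc2c(Cl)ncnc21` gives 7410 nM in this assay. Compound 3 `ClCc1ccccc1Cn1cnc2ncnc(Cl)c21` gives 6910 nM in this assay; the values of compound 2 and compound 3 lie within the usual scatter of one another. Compound 4 `ClCc1ccccc1Cn1cnc2nc(Cl)nc(Cl)c21` has not yet been measured in this assay.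

The cores of compound 2 and compound 3 are built from the same atoms joined differently; the difference between the two cores is not broken down here.

The change from compound 2 to compound 1 is chloro in place of hydrogen on an aromatic carbon and it gave a 5.4-fold lower number from compound 2 to compound 1 (0.73 log units; beyond the scatter). The change from compound 3 to compound 4 is chloro in place of hydrogen on an aromatic carbon. The place is described in identical words in both cases, so this is the same change, occurring twice among these four compounds.

For compound 4 a step of a 4.9-fold lower number from compound 3 to compound 4 (0.69 log units; beyond the scatter) is expected in this assay, because the same change on the core of compound 2 gave a 5.4-fold lower number from compound 2 to compound 1 (0.73 log units; beyond the scatter). That expectation rests on one earlier instance only. Compound 4 is estimated at 1400 nM, with an expected range from 600 nM to 3500 nM.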

Compound 4, concentration for total growth inhibition: 910 nM
Beside the measured number, compound 4's estimate is 1.5-fold (0.19 log units) above it; low and high end bracket the measured number.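

Chloro in place of hydrogen on an aromatic carbon again lowers the number on the second core in this assay, the step being a 7.6-fold lower number from compound 3 to compound 4 (0.88 log units; beyond the scatter). Set side by side, the two instances agree in direction and size: the same change on two cores in this assay, a 5.4-fold lower number (0.73 log units; beyond the scatter) from compound 2 to compound 1 and a 7.6-fold lower number (0.88 log units; beyond the scatter) from compound 3 to compound 4, 1.4-fold (0.15 log units) apart, within the scatter of two such steps. Within this one read-out, the change therefore carries from the core of compound 2 to the core of compound 3 with little difference in size, but two pairs of compounds do not establish a general rule for other cores, nor do they explain why the number falls.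

The compounds shown leave open whether an amine or a methoxy group on that same aromatic carbon would move the number in the same way as chloro. They also leave open whether the step would persist with a longer chain in place of the chloromethyl group that all four compounds share.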